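Phenyl for pyridin-3-yl: an expected half-life

The compounds below may be only part of what the source reports. "The series", "measured", "known", "first", "only" and "open" are said of these compounds alone.

In an ADME assay on microsomes from liver (Mus musculus, strain CD-1) for metabolic stability, read by LC-MS, with a stated time of 60 min, tested at 20 uM (a higher number here means that the compound lasts longer, a lower number that the compound disappears faster), compound 1 `CC(Sc1nc2nn(CC3COC3)cc2c(=O)n1-c1ccccc1)c1ccccc1` gives 0.317 h. Compound 2 `CC(Sc1nc2nn(C3COC3)cc2c(=O)n1-c1ccccc1)c1cccnc1` gives 0.045 h, the lower of the two numbers, and the gap between them lies beyond the usual scatter. Compound 3 `CC(Sc1nc2nn(C3COC3)cc2c(=O)n1-c1ccccc1)c1ccccc1` differs from compound 2 by phenyl in place of pyridin-3-yl on a saturated chain carbon bound to a saturated chain carbon and a sulfur. Going by the values given here, no measured pair shows this change alone, so the expectation is loose. Among the compounds with values here, a rise beyond the scatter in this assay is expected, with compound 1 at 0.317 h as the only higher number. The expected step is a 3.3-fold higher number from compound 2 to compound 3 (0.52 log units; beyond the scatter). For compound 3 the estimate is 0.15 h, within 0.06 h to 0.4 h.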

Compound 3, half-life: 0.783 h
For compound 3 the middle estimate is 5.2-fold (0.72 log units) below the measured one; the whole stated range lies below it.
By their numbers in this assay, from the lowest: compound 2; then compound 1; then compound 3.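

In this assay, phenyl in place of pyridin-3-yl on a saturated chain carbon bound to a saturated chain carbon and a sulfur now reads as a single change, with a 17-fold higher number from compound 2 to compound 3 (1.24 log units; beyond the scatter) as a large step. With 1-phenylethyl kept, oxetan-3-yl in place of (oxetan-3-yl)methyl on an aromatic nitrogen gives a 2.5-fold higher number from compound 1 to compound 3 (0.39 log units; beyond the scatter) as a modest step, so the half-life responds at both places. Nothing available accounts for either step.

Open: how a fluorophenyl group would read on that saturated chain carbon, and how a longer chain would read on the aromatic nitrogen.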